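This account rests on a few compounds, and the source may have more. Where it says the series, first, only, none or still open, it means among the compounds named here.

Measured compounds:
Compound 1 `COc1cccc(CNC(=O)c2nc(Br)c3cccnc3c2N[C@H]2CC[C@H](N)CC2)c1` gives 7000 nM
Compound 2 `N[C@H]1CC[C@H](Nc2c(C(=O)NCc3ccc(F)cc3)nc(Br)c3cccnc23)CC1` gives 6000 nM
Compound 3 `N[C@H]1CC[C@H](Nc2c(C(=O)NCc3cccc(C(F)(F)F)c3)nc(Br)c3cccnc23)CC1` gives 4200 nM

All three were tested in a functional assay on MDA-MB-435 cells (Homo sapiens) for cytotoxicity, read by MTT assay, with a stated time of 72 h (a higher number here means a weaker inhibitor, a lower number a stronger inhibitor), and compound 3, at 4200 nM there, stands level with the other two: the steps of a 1.4-fold lower number from compound 2 to compound 3 (0.15 log units; within the scatter) and a 1.7-fold lower number from compound 1 to compound 3 (0.22 log units; within the scatter) are both small.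

Compound 4 `N[C@H]1CC[C@H](Nc2c(C(=O)NC3CCCCC3)nc(Br)c3cccnc23)CC1` has cyclohexyl in place of 3-(trifluoromethyl)benzyl on an amide-type nitrogen, a change counted as cyclohexyl in place of 3-(trifluoromethyl)benzyl on an amide-type nitrogen on the shared core. The remaining measured step of a 1.2-fold lower number from compound 1 to compound 2 (0.07 log units; within the scatter) is just as small. Each of these three steps only trades one substituted benzyl group for another, so none of them removes the aromatic ring or tests a cyclohexyl group. They give only indirect guidance, and no step beyond the scatter is firmly expected in this assay in either direction.

The estimated move is a 1.4-fold higher number from compound 3 to compound 4 (0.15 log units; within the scatter) and its direction is uncertain. For compound 4 the estimate is 6000 nM with 2500 nM to 14000 nM as its expected range.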

Compound 4, half-maximal inhibitory concentration: > 10000 nM
Compound 4 ended at the assay's limit; the forecaster's own chance of this, stated with the estimate: 10%; middle value at least 1.6-fold (0.22 log units) away from the limit.
By their numbers in this assay, from the lowest: compounds 3, 2 and 1 (each within the scatter of the next). At a limit, above all of these: compound 4.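

In this assay compound 4 gives > 10000 nM, which is a limit of the assay and not a number: the limit of > 10000 nM in this assay, at which 1 of the 4 values shown sits.

Cyclohexyl in place of 3-(trifluoromethyl)benzyl on the amide-type nitrogen gives an at least 2.3-fold higher number from compound 3 to compound 4 (0.37 log units; beyond the scatter) and is the only step here that lies beyond the scatter, while the exchanges among substituted benzyl groups all stayed within it. This shows that the position is not indifferent to every change, although the aromatic benzyl groups could be exchanged with little effect. The steps of an at least 1.6-fold higher number from compound 2 to compound 4 (0.22 log units; that floor lies within the scatter) and an at least 1.4-fold higher number from compound 1 to compound 4 (0.15 log units; that floor lies within the scatter) have floors within the scatter and so establish no difference on their own.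

Going by these compounds, whether an unsubstituted benzyl, a phenyl group set directly on the nitrogen or a longer chain such as phenethyl would keep the numbers of compounds 1 to 3 stays open. On these data alone, it also stays open whether the aromatic ring itself matters, or whether cyclohexyl in particular is what this position does not accept.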